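A few compounds are considered here, and "the series" means these few. Any claim that something is new, unique, unknown or untested is made for them only; others in the source may bear on it.

Series notes. Compound 1 `Cn1cc(SCC(=O)N(Cc2ccccc2)Cc2ccccc2)c2ccccc21` and compound 2 `O=C(CSc1c[nH]c2cccc(Br)c12)N(Cc1ccccc1)Cc1ccccc1` carry two benzyl groups on the amide nitrogen; compound 3 `CN(Cc1ccccc1)C(=O)CSc1c[nH]c2ccccc12` carries one benzyl and one methyl there. In an ADME assay on HEK-293T cells (Homo sapiens) for cytotoxicity, read by CCK-8 assay, with a stated time of 24 h (a lower number here means that less compound is tolerated, a higher number that more compound is tolerated), compound 1 gives 91200 nM and compound 2 gives 25700 nM. In this assay compound 3 gives > 100000 nM, which is a limit of the assay and not a number. Compound 3 thus sits at the limit of > 100000 nM in this assay, at which 1 of the 3 values shown sits, the top of what is shown. Compound 4 `O=C(CSc1c[nH]c2ccccc12)N(Cc1ccccc1)Cc1ccccc1` is the next step from compound 3: phenyl in place of hydrogen on a saturated chain carbon bound to an amide-type nitrogen. Among the compounds with values here, no step between measured compounds is available here, so the size for compound 4 is an expectation only, drawn from compound 1 with 91200 nM and compound 2 with 25700 nM. The expected step is an at least 1.2-fold lower number from compound 3 to compound 4 (0.09 log units; that floor lies within the scatter), toward a less tolerated compound if anything. Compound 4 is expected at 80000 nM, with a range from 30000 nM to 200000 nM.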

Compound 4, half-maximal cytotoxic concentration: > 100000 nM
Compound 4: only a limit was reported (the forecaster's own chance of this, stated with the estimate: 40%); at least 1.2-fold (0.09 log units) between middle value and limit.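

In this assay, within the data shown here, hydrogen in place of bromo on an aromatic carbon gives an at least 3.8-fold higher number from compound 2 to compound 4 (0.59 log units; beyond the scatter), so the bromo group of compound 2 is the one change here with a step beyond the scatter. Hydrogen in place of methyl on an aromatic nitrogen gives an at least 1.0-fold higher number from compound 1 to compound 4 (0.04 log units; that floor lies within the scatter), and that floor shows no readable change. Compound 4 stands at a limit of the assay, not a number, and the step for phenyl in place of hydrogen on a saturated chain carbon bound to an amide-type nitrogen cannot be read: the limit of > 100000 nM in this assay, at which 2 of the 4 values shown sit.

Going by these compounds, whether that phenyl lowers tolerance at all remains open. So does the effect of an amine or a carboxylic acid at that chain carbon.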